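This account rests on a few compounds, and the source may have more. Where it says the series, first, only, none or still open, it means among the compounds named here.

Within the data shown here, compound 1 `Nc1ccccc1NC(=O)c1ccc(Cn2cnc3c(Nc4ccccc4)nc(Cl)nc32)cc1` gives 71.4% in a functional assay on HCT-116 cells (Homo sapiens) for antiproliferative activity, read by CCK-8 assay, with a stated time of 72 h, tested at 2 uM (on this read-out lower numbers stand for a weaker effect and higher numbers for a stronger effect at the one concentration tested), and compound 2 `Nc1ccccc1NC(=O)c1ccc(Cn2cnc3c(NCc4ccccc4)nc(Cl)nc32)cc1` gives 68.3%; the only measured step is a number 3.1 percentage points lower from compound 1 to compound 2 (within the scatter). Compound 3 `Nc1ccccc1NC(=O)/C=C/c1ccc(Cn2cnc3c(Nc4cccc(OC(F)(F)F)c4)nc(Cl)nc32)cc1` gives 2.8%, the lowest of the three values, with compound 2 nearest and compound 1 furthest, both beyond the scatter. Compound 4 `Nc1ccccc1NC(=O)c1ccc(Cn2cnc3c(Nc4cccc(OC(F)(F)F)c4)nc(Cl)nc32)cc1` differs from compound 3 in one place: (2-aminophenyl)carbamoyl in place of 2-((2-aminophenyl)carbamoyl)ethenyl on an aromatic carbon. Among the measured compounds shown here, no measured step covers this change, and the one step known, a number 3.1 percentage points lower from compound 1 to compound 2 (within the scatter), sits at another site and is within the scatter. Compound 1 with 71.4% and compound 2 with 68.3% both carry the (2-aminophenyl)carbamoyl group that enters in compound 4, so an upward step is expected, a number 52.2 percentage points higher from compound 3 to compound 4 (beyond the scatter), though with wide uncertainty. Compound 4 is estimated at 55%, between 15% and 80%.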

Compound 4, a percentage reported as inhibition, at one concentration (the size of the read-out at that concentration, not a potency): 1.6%
The estimate for compound 4 lay 53.4 percentage points above the measured number; measured number below the stated range.
By their numbers in this assay, from the lowest: compounds 4 and 3 (each within the scatter of the next); then compounds 2 and 1 (each within the scatter of the next).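

In this assay, exchanging the 2-((2-aminophenyl)carbamoyl)ethenyl group for (2-aminophenyl)carbamoyl on the aromatic carbon brings no recovery, with a number 1.2 percentage points lower from compound 3 to compound 4 (within the scatter). The (2-aminophenyl)carbamoyl group therefore does not by itself secure the high read-out. The large loss instead appears on the other side of the shared core, with a number 69.8 percentage points lower from compound 1 to compound 4 (beyond the scatter) when trifluoromethoxy replaces hydrogen and a number 66.7 percentage points lower from compound 2 to compound 4 (beyond the scatter) when 3-(trifluoromethoxy)phenyl replaces benzyl. The compounds shown leave open whether a fluorine or a methoxy group in place of trifluoromethoxy would keep the read-out. No available evidence explains the loss.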